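This account rests on a few compounds, and the source may have more. Where it says the series, first, only, none or still open, it means among the compounds named here.

Measured compounds:

Compound 1 `COc1ncc(-c2cc(OC3CCCCC3)c3nc(N)nc(C)c3c2)cc1NS(=O)(=O)c1ccc(F)cc1F`: 96 nM
Compound 2 `COc1ncc(-c2cc(OCC3CCOCC3)c3nc(N)nc(C)c3c2)cc1NS(=O)(=O)c1ccc(F)cc1F`: 21 nM
Compound 3 `CNc1nc(C)c2cc(-c3cnc(OC)c(NS(=O)(=O)c4ccc(F)cc4F)c3)cc(OCC3CCOCC3)c2n1`: 400 nM

All three were tested in a functional assay on NCI-H460 cells (Homo sapiens) for cytotoxicity, read by MTT assay, with a stated time of 96 h; a higher number here means a weaker inhibitor, a lower number a stronger inhibitor. Compound 2 gives 21 nM and stands lowest of the three. Compound 1 differs from compound 2 in one place, (cyclohexyl in place of (oxan-4-yl)methyl on an oxygen on an aromatic ring), and this change brings a 4.6-fold higher number from compound 2 to compound 1 (0.66 log units; beyond the scatter). Compound 3 differs from compound 2 in another place, (methyl in place of hydrogen on a nitrogen on an aromatic ring), and this change brings a 19-fold higher number from compound 2 to compound 3 (1.28 log units; beyond the scatter), so compound 3, at 400 nM, is the highest number of the three.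

Compound 4 `CNc1nc(C)c2cc(-c3cnc(OC)c(NS(=O)(=O)c4ccc(F)cc4F)c3)cc(OC3CCCCC3)c2n1` has not been measured in this assay. It differs from compound 3 in one place, (cyclohexyl in place of (oxan-4-yl)methyl on an oxygen on an aromatic ring). Going by the values given here, this is the same change as the one from compound 2 to compound 1, made on a core that carries the methylamino group rather than the amino group, as the difference between compound 2 and compound 3 shows. Since the surroundings of the change are the same in both pairs, the expectation rests on compound 1 and compound 2, where the step was a 4.6-fold higher number from compound 2 to compound 1 (0.66 log units; beyond the scatter), and on compound 3 as the starting point, at 400 nM. The step from compound 3 to compound 4 in this assay is therefore expected to be a 4.0-fold higher number from compound 3 to compound 4 (0.60 log units; beyond the scatter), similar to the earlier one. On that basis compound 4 is estimated at 1600 nM, with a likely range from 500 nM to 5000 nM.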

Compound 4, half-maximal inhibitory concentration: 1700 nM
The estimate for compound 4 lay 1.1-fold (0.03 log units) below the measured number, and the stated range covers the measured number.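

Putting cyclohexyl in place of (oxan-4-yl)methyl on the oxygen brings a 4.3-fold higher number from compound 3 to compound 4 (0.63 log units; beyond the scatter) in this assay, and this step carries over from the amino core to the methylamino core with its size essentially kept: the same change on two cores in this assay, a 4.6-fold higher number (0.66 log units; beyond the scatter) from compound 2 to compound 1 and a 4.3-fold higher number (0.63 log units; beyond the scatter) from compound 3 to compound 4, 1.1-fold (0.03 log units) apart, within the scatter of two such steps. The other change behaves the same way, as methyl in place of hydrogen on the nitrogen brings an 18-fold higher number from compound 1 to compound 4 (1.25 log units; beyond the scatter) with cyclohexyl on the oxygen, matching its size with (oxan-4-yl)methyl there: the same change on two cores in this assay, a 19-fold higher number (1.28 log units; beyond the scatter) from compound 2 to compound 3 and an 18-fold higher number (1.25 log units; beyond the scatter) from compound 1 to compound 4, 1.1-fold (0.03 log units) apart, within the scatter of two such steps. Across these four compounds, then, each change keeps its size whichever form of the other place is present, but a single set of four compounds in one cell assay gives no rule for other groups or other cores, and it does not show why either change raises the number.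

The compounds shown leave open how the number responds to other groups on the oxygen, such as a plain ethyl group or a longer chain ending in an amine, and to other groups on the nitrogen, such as an ethyl or acetyl group. They also leave open whether the two steps would keep their size together with such groups.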